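A few compounds are considered here, and "the series" means these few. Any claim that something is new, unique, unknown or untested is made for them only; others in the source may bear on it.

In an assay on isolated protein (urine) for inhibition of Myeloperoxidase (Homo sapiens), with a stated time of 5 min (on this read-out lower numbers stand for stronger inhibition and higher numbers for weaker inhibition), compound 1 `NCCCc1c[nH]c2c(F)cccc12` gives 24 nM, the lowest of the two numbers recorded. Compound 3 `NCC(N)CCc1c[nH]c2ccc(F)cc12` gives 60 nM, a gap from compound 1 that lies beyond the scatter. For compound 2 `CCCc1c[nH]c2ccc(F)cc12` the assay reports only a limit, > 100 nM, which is the limit of > 100 nM in this assay, at which 1 of the 3 values shown sits. Going by the values given here, the single measured step between neighbours, an at least 1.6-fold lower number from compound 2 to compound 3 (0.22 log units; that floor lies within the scatter), concerns a different group and is the only guide on hand. Compound 4 `NCCSCCCc1c[nH]c2c(F)cccc12` carries (2-aminoethyl)sulfanyl in place of amino on a saturated chain carbon, three bonds along the chain from an aromatic carbon. Among the compounds with values here, no measured step shows a change of this kind, so no step beyond the scatter is expected, the terminal amine being kept. Compound 4 is therefore estimated at 40 nM, between 15 nM and 120 nM. That estimate means a 1.7-fold higher number from compound 1 to compound 4 (0.22 log units; within the scatter), expected to stay close to the scatter.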

Compound 4, half-maximal inhibitory concentration: > 100 nM
Compound 4 ended at the assay's limit; the forecaster's own chance of this, stated with the estimate: 10%; middle value at least 2.5-fold (0.39 log units) away from the limit.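

Putting (2-aminoethyl)sulfanyl in place of amino on a saturated chain carbon, three bonds along the chain from an aromatic carbon, gives an at least 4.1-fold higher number from compound 1 to compound 4 (0.61 log units; beyond the scatter). This is the first step shown at this chain end that lies beyond the scatter, and it shows that keeping a terminal amine is not enough to hold the number of compound 1. Compound 4 sits at a limit of the assay, so the step gives only a floor: the limit of > 100 nM in this assay, at which 2 of the 4 values shown sit.

On these data alone, what stays open is whether the sulfur or the added length drives this step. A plain longer carbon chain ending in an amine would separate the two.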